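From a Phenyl Ketone to an Oxazolyl Ketone

This account rests on a few compounds, and the source may have more. Where it says the series, first, only, none or still open, it means among the compounds named here.

Measured compounds:
compound 1, `C[C@@H]1C=NN(C(=O)C(C)(C)C)[C@@H]1c1ccccc1`, 0.45 h
compound 2, `O=C(c1ccccc1)N1CCC(C(=O)N2N=CCC2c2ccccc2)CC1`, 1.72 h
compound 3, `CC(C)(C)C(=O)N1CCSC1c1ccccc1`, 0.3 h

Of the compounds shown here, three have been measured in an ADME assay on microsomes (Homo sapiens) for metabolic stability; a higher number here means that the compound lasts longer, a lower number that the compound disappears faster. Among them compound 2 stands highest, with 1.72 h; the nearest number is that of compound 1 at 0.45 h, and the furthest is that of compound 3 at 0.3 h, both of these gaps lying beyond the usual scatter of the assay. Going by the values given here, the three compounds differ in more than one place, so no single step between them can be read off.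

Compound 4, `O=C(c1cocn1)N1CCC(C(=O)N2N=CCC2c2ccccc2)CC1`, is the next compound to be measured in this assay. It differs from compound 2 in one place: 1,3-oxazol-4-yl in place of phenyl on a carbonyl carbon. Among the compounds with values here, no measured pair shows this same change, so there is no step of known size to lean on. The step from compound 2 to compound 4 is expected to be small, a 1.2-fold lower number from compound 2 to compound 4 (0.09 log units; within the scatter), most likely within the scatter, with a slight lean downward. The half-life of compound 4 in this assay is therefore estimated at 1.4 h, within a range of 0.6 h to 3.4 h.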

Compound 4, half-life: > 2.75 h
Compound 4: no number, only a limit (the forecaster's own chance of this, stated with the estimate: 5%); at least 1.9-fold (0.29 log units) between middle value and limit.
By their numbers in this assay, from the lowest: compounds 3 and 1 (each within the scatter of the next); then compound 2. At a limit, above all of these: compound 4.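

In this assay compound 4 gives > 2.75 h, which is a limit of the assay and not a number. Putting 1,3-oxazol-4-yl in place of phenyl on this carbonyl carbon gives an at least 1.5-fold higher number from compound 2 to compound 4 (0.20 log units; that floor lies within the scatter), so this first step at the position shows no loss of half-life, although its floor does not clear the scatter. The true size of the step cannot be read, as the reading for compound 4 stops at a limit: the limit of > 2.75 h in this assay, at which 1 of the 4 values shown sits.

The compounds shown leave open whether this result is particular to 1,3-oxazol-4-yl or would also hold for another ring on the same carbonyl carbon, such as 1,3-thiazol-4-yl or pyridin-2-yl. They also leave open whether the same change would behave alike on a different core, such as that of compound 1.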